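A few compounds are considered here, and "the series" means these few. Any claim that something is new, unique, unknown or untested is made for them only; others in the source may bear on it.

The series shares the core of compound 1 `C/C(=C\c1cc(-c2ccccc2)cs1)C(N)=O`. In a functional assay on T-24 cells (Homo sapiens) for cytotoxicity, read by CCK-8 assay, with a stated time of 24 h (on this read-out higher numbers stand for weaker inhibition and lower numbers for stronger inhibition), compound 1 gives only a limit of the assay, > 50000 nM. Compound 2 `C/C(=C\c1cccc(-c2ccccc2)c1)C(N)=O` likewise reaches only a limit in this assay, > 50000 nM. Compound 3 `C/C(=C\c1cc(-c2ccccc2C)cs1)C(N)=O` again shows a limit in this assay, > 50000 nM. The step from compound 1 to compound 3, methyl in place of hydrogen on an aromatic carbon, stays unreadable: a step that the two limits leave unreadable from compound 1 to compound 3. All three values sit at the same limit (the limit of > 50000 nM in this assay, at which 3 of the 3 values shown sit), so compound 1 cannot be placed on a scale of numbers within this set. Compound 4 `C/C(=C\c1cc(-c2ccc(S(C)(=O)=O)cc2)cs1)C(N)=O` differs from compound 1 by methylsulfonyl in place of hydrogen on an aromatic carbon, placed on an aromatic carbon of a six-membered aromatic ring of carbon only, para to a large group. For the measured compounds named here, no measured step bears on this change, and the single step that exists in the set is unreadable. For compound 4 the step that the limit leaves unreadable from compound 1 to compound 4 is expected to be nothing beyond the scatter. The estimate for compound 4 in this assay is 60000 nM, between 15000 nM and 200000 nM, and most probably again only a limit.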

Compound 4, half-maximal inhibitory concentration: > 50000 nM
Compound 4: a limit, no number (the forecaster's own chance of this, stated with the estimate: 85%); the middle value does not contradict the limit.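

In this assay no step can be read between compound 1 and compound 4, as both values are limits and not numbers: the limit of > 50000 nM in this assay, at which 4 of the 4 values shown sit. The compounds shown leave open whether any change on the shared core brings a value inside the range of this assay and how large such a step would be.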